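A Benzylamine Replaces Pyrrolidine: Estimating Compound 4

The source may hold more compounds than are shown below. What is called first, only, known or untested is meant among the compounds shown, and "the series" means these compounds.

The series was examined in a functional assay on L02 cells (Homo sapiens) for inhibition, read by Griess assay, with stated times of 1 h and 24 h; on this read-out lower numbers stand for stronger inhibition and higher numbers for weaker inhibition. Compound 1 `Fc1ccc(CNc2nc(/C=C/c3ccccc3)nc3ccsc23)cc1` reaches only the limit of the assay, > 1000000 nM. Compound 2 `C(=C/c1ccco1)\c1nc(NCc2ccccc2)c2sccc2n1` likewise gives only a limit, > 1000000 nM. Compound 3 `COc1cc(/C=C/c2nc(N3CCCC3)c3sccc3n2)cc(OC)c1OC` is the one member with a number: in this assay compound 3 gives 681000 nM, and it therefore stands as the only number shown, while the other two values sit at the limit of > 1000000 nM in this assay, at which 2 of the 3 values shown sit. Among the compounds with values here, no pair of measured compounds differs in a single place, so no measured step can be quoted.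

Compound 4 `COc1ccc(CNc2nc(/C=C/c3cc(OC)c(OC)c(OC)c3)nc3ccsc23)cc1` has not yet been measured. It differs from compound 3 in one place: (4-methoxybenzyl)amino in place of pyrrolidin-1-yl on an aromatic carbon. Compound 1 and compound 2, which also carry a benzylamino group on the shared core, both give limits, whereas compound 3 with its pyrrolidin-1-yl gives a number; this is all the data show, and it points toward weaker inhibition for compound 4. The step of a 1.3-fold higher number from compound 3 to compound 4 (0.12 log units; within the scatter) is expected to run toward weaker inhibition and to be modest, with a real chance that only a limit is reported. Compound 4 is estimated at 900000 nM in this assay, within a range from 350000 nM to 2500000 nM.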

Compound 4, half-maximal inhibitory concentration: > 1000000 nM
Compound 4 gave a limit, no number (the forecaster's own chance of this, stated with the estimate: 50%); at least 1.1-fold (0.04 log units) between middle value and limit.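

Replacing pyrrolidin-1-yl with (4-methoxybenzyl)amino on the aromatic carbon next to the ring nitrogen gives, in this assay, an at least 1.4-fold higher number from compound 3 to compound 4 (0.16 log units; that floor lies within the scatter). Within the data shown here, this is the first view of this position changed on its own, which compounds 1 and 2 could not give, since neither differs from compound 3 in a single place. The step has only a floor, and because that floor lies within the scatter, the result does not establish a real difference between the two compounds; it shows only that the change leaves no measurable number, and compound 4 joins the compounds reported at the assay's limit: the limit of > 1000000 nM in this assay, at which 3 of the 4 values shown sit.

Going by these compounds, the true size of the step stays open, as does whether the outcome follows the benzyl ring, the 4-methoxy group or the amine hydrogen that enters with the new group. How a piperidin-1-yl, a morpholin-4-yl or a dimethylamino group would read at this position, or a plain benzylamino group on the otherwise unchanged compound 3, cannot be told from the compounds shown.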